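Ethoxy in place of piperidin-1-yl: working notes

A few compounds are considered here, and "the series" means these few. Any claim that something is new, unique, unknown or untested is made for them only; others in the source may bear on it.

- compound 1 `O=c1ccc2nc(-c3ccccc3)nn(-c3ccccc3)c-2c1`: 230 nM
- compound 2 `CNc1cc2nc(-c3ccccc3)nn(-c3ccccc3)c-2cc1=O`: 980 nM
- compound 3 `O=c1cc2n(-c3ccccc3)nc(-c3ccccc3)nc-2cc1N1CCCCC1`: 610 nM

All three values come from a functional assay on DU-145 cells (Homo sapiens) for cytotoxicity, read by MTT assay, with a stated time of 72 h; a lower number here means a stronger inhibitor, a higher number a weaker inhibitor. Compound 3 lies at the upper end of these numbers together with compound 2, and the gap between the two is within the scatter.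

The next compound, compound 4 `CCOc1cc2nc(-c3ccccc3)nn(-c3ccccc3)c-2cc1=O`, is unmeasured. The change is ethoxy in place of piperidin-1-yl on an aromatic carbon, with ethoxy in place of piperidin-1-yl on an aromatic carbon. Going by the values given here, no measured compound carries ethoxy, so only the steps at this same carbon bear on it. Two modest steps start from hydrogen: a 4.3-fold higher number from compound 1 to compound 2 (0.63 log units; beyond the scatter), and a 2.7-fold higher number from compound 1 to compound 3 (0.42 log units; beyond the scatter). Exchanging one substituent for the other gave a 1.6-fold lower number from compound 2 to compound 3 (0.21 log units; within the scatter). Going by these compounds, on that single exchange, no step beyond the scatter is expected in this assay, and the direction stays open. The expected step is a 1.2-fold lower number from compound 3 to compound 4 (0.07 log units; within the scatter). For compound 4 the estimated value is 520 nM, with an expected range of 220 nM to 1200 nM.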

Compound 4, half-maximal inhibitory concentration: > 5000 nM
Compound 4: a limit, no number (the forecaster's own chance of this, stated with the estimate: 1%); at least 9.6-fold (0.98 log units) between middle value and limit.
By their numbers in this assay, from the lowest: compound 1; then compounds 3 and 2 (each within the scatter of the next). At a limit, above all of these: compound 4.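

In this assay compound 4 stands at a limit, not a number: the limit of > 5000 nM in this assay, at which 1 of the 4 values shown sits.

At this aromatic carbon, the choice of substituent now counts for more than compounds 2 and 3 could show: methylamino and piperidin-1-yl lie within the scatter of each other, whereas ethoxy gives an at least 8.1-fold higher number from compound 3 to compound 4 (0.91 log units; beyond the scatter) and an at least 5.1-fold higher number from compound 2 to compound 4 (0.70 log units; beyond the scatter). Against the unsubstituted compound the change is large, with an at least 21-fold higher number from compound 1 to compound 4 (1.33 log units; beyond the scatter), so compound 1 keeps the lowest number and ethoxy is the poorest of the three substituents shown at this carbon.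

With ethoxy as the only oxygen-linked group, the compounds shown cannot separate the effect of the oxygen link from that of this particular chain. Methoxy, a free hydroxyl or a longer alkoxy chain at this carbon would address that, and morpholin-4-yl would test a ring that carries both nitrogen and oxygen.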